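One Methoxy Fewer: From Compound 2 to Compound 4

The source may report more compounds than this note shows. Statements on the series, on what has been measured and on what is new or still open speak of the compounds shown alone.

Compound 2 `COc1cc(-c2cc(/C=C/C(=O)c3ccc(N)cc3)[nH]n2)cc(OC)c1OC` gives 1060 nM in a functional assay on LOX IMVI cells (Homo sapiens) for inhibition, read by sulforhodamine B assay, with a stated time of 48 h; a higher number here means a weaker inhibitor of growth, a lower number a stronger inhibitor of growth.
Compound 3 `COc1ccc(C(=O)/C=C/c2cc(-c3cc(OC)c(OC)c(OC)c3)n[nH]2)cc1` gives 1580 nM in this assay.

Compound 1 `COc1ccc(-c2cc(/C=C/C(=O)c3ccc(N)cc3)[nH]n2)cc1` gives "not determined" (no result reported) in this assay, so no number is available for it. Among the two numbers available, compound 2 carries the lower one, but the step of a 1.5-fold higher number from compound 2 to compound 3 (0.17 log units; within the scatter) lies within the scatter, so compound 2 and compound 3 cannot be ranked against each other.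

Compound 4 `COc1ccc(-c2cc(/C=C/C(=O)c3ccc(N)cc3)[nH]n2)cc1OC` differs from compound 2 by hydrogen in place of methoxy on an aromatic carbon. Among the measured compounds shown here, no measured step in this set removes a methoxy group; the only measured step, a 1.5-fold higher number from compound 2 to compound 3 (0.17 log units; within the scatter), exchanges a different group on the other end of the molecule and bears on the present change only in showing that small edits on an aromatic carbon left the number close to unchanged. On that thin basis, compound 4 is expected to stay near compound 2, with at most a modest rise in the number. The expected step of a 1.4-fold higher number from compound 2 to compound 4 (0.15 log units; within the scatter) is therefore small. Compound 4 is estimated at 1500 nM, within a range from 500 nM to 5000 nM.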

Compound 4, concentration for 50% growth inhibition: 1920 nM
For compound 4 the middle estimate is 1.3-fold (0.11 log units) below the measured one, and the stated range covers the measured number.
By their numbers in this assay, from the lowest: compounds 2, 3 and 4 (each within the scatter of the next).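

In this assay, putting hydrogen in place of the methoxy on this aromatic carbon, ortho to a methoxy group and meta to a large group, gives a 1.8-fold higher number from compound 2 to compound 4 (0.26 log units; within the scatter) and so produces no change that can be told from scatter. Among the compounds shown here, the earlier compounds offered only an exchange of amino for methoxy on another aromatic carbon, whereas this step is the first reading on the loss of a methoxy group itself, and it shows that compound 2 and compound 4 cannot be ranked. No measurement at hand bears on why the number responds in this way.

As far as these compounds go, whether another group in this place, such as a hydroxyl, a fluorine or an ethoxy, would leave the number as close remains open. The loss of a further methoxy group also remains unread, since compound 1 gives "not determined" (no result reported) in this assay.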